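Acyl chain ester versus amide: cytotoxicity notes

The source may hold more compounds than are shown below. What is called first, only, known or untested is meant among the compounds shown, and "the series" means these compounds.

Measured in an ADME assay on Huh-7 cells (Homo sapiens) for cytotoxicity, with a stated time of 72 h; on this read-out lower numbers stand for higher toxicity in this test and higher numbers for lower toxicity in this test:
- compound 1 `COC(=O)CCCC(=O)n1c(=O)c(C)cn([C@@H]2O[C@H](CO[Si](C)(C)C(C)(C)C)[C@@]3(OS(=O)(=O)C=C3N)[C@H]2O[Si](C)(C)C(C)(C)C)c1=O` gives > 100000 nM (a limit of the assay)
- compound 2 `CNC(=O)CCCC(=O)n1c(=O)c(C)cn([C@@H]2O[C@H](CO[Si](C)(C)C(C)(C)C)[C@@]3(OS(=O)(=O)C=C3N)[C@H]2O[Si](C)(C)C(C)(C)C)c1=O` gives > 100000 nM (a limit of the assay)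

Compound 2 stands at > 100000 nM in this assay and this is a limit, not a number. The same holds for the whole set, which comes down to the limit of > 100000 nM in this assay, at which 2 of the 2 values shown sit, and nothing more. The next compound is compound 3 `Cc1cn([C@@H]2O[C@H](CO[Si](C)(C)C(C)(C)C)[C@@]3(OS(=O)(=O)C=C3N)[C@H]2O[Si](C)(C)C(C)(C)C)c(=O)n(C(=O)CCCC(=O)OC(C)(C)C)c1=O`, which has tert-butoxy in place of methylamino on a carbonyl carbon. The counted difference reads tert-butoxy in place of methylamino on a carbonyl carbon and the rest of the structure stays as it is.

Going by the values given here, only one measured step bears on this change, namely a step that the two limits leave unreadable from compound 1 to compound 2 at the same carbonyl carbon. It gives no size to carry over, so no shift in either direction can be derived from it. The working expectation in this assay is therefore no change beyond the scatter, with another limit reading the most likely result.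

The expected step is a number no higher from compound 2 to compound 3 (the limit leaves the size open) in this estimate. For compound 3 the estimated value is 100000 nM with an expected range from 40000 nM to 200000 nM in this assay.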

Compound 3, half-maximal cytotoxic concentration: > 100000 nM
Compound 3 gave a limit, no number; the forecaster's own chance of this, stated with the estimate: 75%; the middle value sits exactly at the limit.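

In this assay no step among compound 1, compound 2 and compound 3 can be read, and each reading is a limit, not a number: the limit of > 100000 nM in this assay, at which 3 of the 3 values shown sit.

As far as these compounds go, how far the cytotoxicity of these three compounds lies past that limit, and whether the group on the carbonyl carbon makes any difference there, stays open.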